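Ester to Acid on a Weak Fatty Acid Amide Hydrolase Inhibitor

The compounds below may be only part of what the source reports. "The series", "measured", "known", "first", "only" and "open" are said of these compounds alone.

Measured compounds:
Compound 1 `OC(CCCCCCc1ccccc1)c1ncc(C(F)(F)F)o1`: in an assay (Rattus norvegicus) for inhibition of Fatty-acid amide hydrolase 1 (Homo sapiens) (a higher number here means a weaker inhibitor, a lower number a stronger inhibitor), compound 1 gives 2300 nM.
Compound 2 `COC(=O)c1cnc(C(O)CCCCCCc2ccccc2)o1`: in this assay compound 2 gives 2000 nM.
Compound 3 `COC(=O)c1ccc(-c2cnc(C(O)CCCCCCc3ccccc3)o2)nc1`: in this assay compound 3 gives > 10000 nM, which is a limit of the assay and not a number.

Going by the values given here, compound 3 therefore stands apart from the other two: it is the one compound whose potency could not be put as a number. It sits at the limit of > 10000 nM in this assay, at which 1 of the 3 values shown sits. Compound 4 `O=C(O)c1ccc(-c2cnc(C(O)CCCCCCc3ccccc3)o2)nc1` differs from compound 3 in one place: hydrogen in place of methyl on an oxygen next to a carbonyl group. Among the compounds with values here, only one measured step exists, a 1.2-fold lower number from compound 1 to compound 2 (0.06 log units; within the scatter), and it concerns a different position and a different pair of groups, so it does not bear on this exchange of methyl for hydrogen. Within the data shown here, no measured pair shows what the move from methoxycarbonyl to carboxy does in this assay. The starting point is a limit, and the change is confined to a single small group. Compound 4 is therefore expected to remain at or near that limit, the estimated step that the limit leaves unreadable from compound 3 to compound 4 amounting to no shift that can be told from the scatter. The estimate for compound 4 is 20000 nM, with a range from 5000 nM to 100000 nM.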

Compound 4, inhibition constant: 45000 nM
The estimate for compound 4 lay 2.3-fold (0.35 log units) below the measured number; measured number inside the range.
By their numbers in this assay, from the lowest: compounds 2 and 1 (each within the scatter of the next); then compound 4.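

Compound 3 gives > 10000 nM in this assay, which is a limit of the assay and not a number. The step from methoxycarbonyl to carboxy on this side group therefore cannot be read, because its starting point is only a limit: the limit of > 10000 nM in this assay, at which 1 of the 4 values shown sits. What compound 4 adds is a number for the larger group: on the same aromatic carbon, 5-carboxypyridin-2-yl gives a much weaker inhibitor than either methoxycarbonyl or trifluoromethyl, with a 23-fold higher number from compound 2 to compound 4 (1.35 log units; beyond the scatter) and a 20-fold higher number from compound 1 to compound 4 (1.29 log units; beyond the scatter).

Still open, as far as these compounds go, is how much of that loss belongs to the carboxy group and how much to the rest of 5-carboxypyridin-2-yl, and whether the ester-to-acid change matters at all in a compound whose ester gives a real number. A carboxy group set directly on that aromatic carbon in place of methoxycarbonyl, or a primary amide at the end of the larger group in place of carboxy, would speak to these questions.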